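Two nonyl chains on a diamino sugar: expected cytotoxicity

The source may report more compounds than this note shows. Statements on the series, on what has been measured and on what is new or still open speak of the compounds shown alone.

Measured so far:
Compound 1, `CCCCCCCCCO[C@@H]1[C@@H](N)[C@@H](O[C@H]2[C@H](O)[C@@H](OCCCCCCCCC)[C@H](N)C[C@@H]2N)O[C@H](CN)[C@H]1O`, gives 78.4%.
Compound 2, `CCCCCCCCCO[C@@H]1[C@@H](N)[C@@H](OCC(O)CNCCCO)O[C@H](CN)[C@H]1OCCCCCCCCC`, gives 89.9%.
Compound 3, `NC[C@H]1O[C@H](O[C@H]2[C@H](O)[C@@H](O)[C@H](N)C[C@@H]2N)[C@H](N)[C@@H](OCCCc2ccc3ccccc3c2)[C@@H]1OCCCc1ccc2ccccc2c1`, gives 87.7%.

All three numbers come from a toxicity assay on the whole organism (J774 cells) for cytotoxicity, with Mus musculus as the target, read by MTT assay, with a stated time of 24 h, tested at 10 uM; a higher number here means a weaker effect of the compound at the concentration tested, a lower number a stronger effect. Compound 2 has the top number of the three, but its gap to compound 3 lies within the usual scatter, so the two cannot be told apart; its gap to compound 1 lies beyond the scatter, and compound 1 is the only one of the three with a clearly stronger effect at the tested concentration.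

Compound 4, `CCCCCCCCCO[C@@H]1[C@@H](N)[C@@H](O[C@H]2[C@H](O)[C@@H](O)[C@H](N)C[C@@H]2N)O[C@H](CN)[C@H]1OCCCCCCCCC`, has not yet been measured. It differs from compound 2 at a single place: 4,6-diamino-2,3-dihydroxycyclohexyl in place of 2-hydroxy-3-((3-hydroxypropyl)amino)propyl on an oxygen on a saturated carbon. The piece that enters is the same ring that compound 1 and compound 3 carry, so compound 4 shares the core of compound 1 while keeping the two nonyl chains of compound 2 on one ring.

Among the measured compounds shown here, no step between two measured compounds is recorded, so the size of the change can only be expected, not read off. For the measured compounds named here, because compound 1, with 78.4%, is the only compound of the three with this ring and a nonyl chain on it, compound 4 is expected to move towards a somewhat stronger effect, with a number 7.9 percentage points lower from compound 2 to compound 4 (within the scatter) of a size that may or may not clear the scatter. Compound 4 is therefore estimated at 82% in this assay, within a range from 66% to 95%.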

Compound 4, a percentage reported as activity, at one concentration (the size of the read-out at that concentration, not a potency): 82.7%
For compound 4 the middle estimate is 0.7 percentage points below the measured one, and the stated range covers the measured number.
By their numbers in this assay, from the lowest: compounds 1, 4, 3 and 2 (each within the scatter of the next, the first and the last beyond it).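

In this assay, replacing 2-hydroxy-3-((3-hydroxypropyl)amino)propyl with 4,6-diamino-2,3-dihydroxycyclohexyl on an oxygen on a saturated carbon gives a number 7.2 percentage points lower from compound 2 to compound 4 (within the scatter), so the two compounds cannot be told apart in this read-out. This first readable step at this position shows that, with both nonyl chains left in place, exchanging an open substituent for one six-membered non-aromatic ring of carbon only, with 5 defined stereocentres, has no effect that can be separated from the usual variation between repeated measurements. No measured information bears on the reason for this result.

The compounds shown leave open whether another substituent at this oxygen, such as a carboxylic acid, a guanidine or a simple primary amine on an ethyl chain, would produce a step beyond the scatter. Among the compounds shown here, they also leave open whether the same exchange would give a similar result with a chain other than nonyl, such as dodecyl, because this single step comes from only one pair of compounds.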